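The source may report more compounds than this note shows. Statements on the series, on what has been measured and on what is new or still open speak of the compounds shown alone.

In a functional assay on PC-3 cells (Homo sapiens) for antiproliferative activity, read by sulforhodamine B assay, with a stated time of 72 h (a higher number here means a weaker inhibitor, a lower number a stronger inhibitor), compound 1 `COc1ncc(-c2ccc3ncc(NCc4ccc(C(F)(F)F)cc4)c(OC)c3c2)cc1NS(=O)(=O)c1ccc(F)cc1F` gives 2880 nM and compound 2 `COc1ncc(-c2ccc3ncc(NCc4ccccc4)c(OC)c3c2)cc1NS(=O)(=O)c1ccc(F)cc1F` gives 4320 nM. Going by the values given here, these two values lie within the scatter of each other, so compound 2 stands level with the only other number available. The next compound, compound 3 `COc1ncc(-c2ccc3ncc(NC(=O)C4CCCCC4)c(OC)c3c2)cc1NS(=O)(=O)c1ccc(F)cc1F`, keeps the shared core but carries a different group on the nitrogen: cyclohexylcarbonyl in place of benzyl on a nitrogen on an aromatic ring, (cyclohexylcarbonyl in place of benzyl on a nitrogen on an aromatic ring). Among the compounds with values here, only one measured step bears on this change, and only indirectly. It puts hydrogen in place of trifluoromethyl on an aromatic carbon and amounts to a 1.5-fold higher number from compound 1 to compound 2 (0.18 log units; within the scatter). That step alters the benzyl group without removing it. Within the data shown here, no measured compound shows what happens when benzyl is lost or cyclohexylcarbonyl enters, so the data point in no direction. A change beyond the scatter in this assay is therefore not expected, although this expectation rests on thin evidence. The estimated step is a 1.2-fold lower number from compound 2 to compound 3 (0.09 log units; within the scatter). For compound 3 the expected value is 3500 nM, within an estimated range of 900 nM to 12000 nM.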

Compound 3, half-maximal inhibitory concentration: 6630 nM
Beside the measured number, compound 3's estimate is 1.9-fold (0.28 log units) below it, and the stated range covers the measured number.
By their numbers in this assay, from the lowest: compounds 1, 2 and 3 (each within the scatter of the next, the first and the last beyond it).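

In this assay, going by these compounds alone, the earlier compounds varied only a substituent on the benzyl group, whereas this change removes the benzyl group altogether, and the exchange of benzyl for cyclohexylcarbonyl on a nitrogen on an aromatic ring gives a 1.5-fold higher number from compound 2 to compound 3 (0.19 log units; within the scatter). Against the unsubstituted benzyl group, then, replacing an aromatic ring of carbon only with a non-aromatic one and adding a carbonyl leaves the number within the scatter, even though the group on this nitrogen is now of a different kind. Against 4-(trifluoromethyl)benzyl, the same replacement gives a 2.3-fold higher number from compound 1 to compound 3 (0.36 log units; beyond the scatter), a modest separation and the only one among these compounds that lies beyond the scatter, and nothing measured here accounts for it.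

The compounds shown leave open whether the carbonyl or the loss of the aromatic ring matters more, since the two enter together; benzoyl or cyclohexylmethyl on the same nitrogen would separate them. They also leave open how a smaller acyl group such as acetyl, or a group carrying an amine, would fare here.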